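Acetamido Replaces Oxazole: Cytotoxicity Expected Unchanged

The source may hold more compounds than are shown below. What is called first, only, known or untested is meant among the compounds shown, and "the series" means these compounds.

Three compounds share one core and differ only in a group on an aromatic carbon. Compound 1 `C=Cc1cccc(C(=O)N2CCCC(C(=O)Nc3ccc(Cl)cc3)C2)c1` carries a vinyl group there, and in an ADME assay on PC-3 cells (Homo sapiens) for cytotoxicity, read by WST assay, tested at 100 uM (on this read-out lower numbers stand for less inhibition and higher numbers for more inhibition at the one concentration tested (going by the name of the read-out)), compound 1 gives 0%. Compound 2 `O=C(Nc1ccc(Cl)cc1)C1CCCN(C(=O)c2cccc(-c3ccco3)c2)C1` carries a furan-2-yl group, and in this assay compound 2 gives 0%. Compound 3 `O=C(Nc1ccc(Cl)cc1)C1CCCN(C(=O)c2cccc(-c3cnco3)c2)C1` carries a 1,3-oxazol-5-yl group, and in this assay compound 3 gives 0%, so compound 3 stands level with compound 1 and compound 2. The three changes in this position gave no change at the digits printed from compound 1 to compound 2 (within the scatter), no change at the digits printed from compound 1 to compound 3 (within the scatter) and no change at the digits printed from compound 2 to compound 3 (within the scatter). Compound 4 `CC(=O)Nc1cccc(C(=O)N2CCCC(C(=O)Nc3ccc(Cl)cc3)C2)c1` is built from compound 3 by the change (acetamido in place of 1,3-oxazol-5-yl on an aromatic carbon). The three measured steps all concern this same position, and none of them moved the read-out, so no step beyond the scatter is expected in this assay either; the expected step is no change at the digits printed from compound 3 to compound 4 (within the scatter). Compound 4 is therefore expected to give 0%, within a range from 0% to 10%.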

Compound 4, a percentage reported as inhibition, at one concentration (the size of the read-out at that concentration, not a potency): 4%
Estimate against measurement, compound 4: 4 percentage points below; the measured number falls inside the stated range.
By their numbers in this assay, from the lowest: compounds 1, 2, 3 and 4 (each within the scatter of the next).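

In this assay, the step to acetamido, a group with no ring and with a hydrogen-bond donor, reads as a number 4 percentage points higher from compound 3 to compound 4 (within the scatter) and, from the other two groups, as a number 4 percentage points higher from compound 2 to compound 4 (within the scatter) and a number 4 percentage points higher from compound 1 to compound 4 (within the scatter) in this same position. This position on the aromatic carbon therefore accepts an open amide group, as well as the vinyl group and the two five-membered aromatic rings, with no step beyond the scatter among the four compounds. No measurement at hand explains the small differences among these numbers. Still open, on these data alone, is whether an amine or a carboxylic acid in this position, or a longer chain in place of the acetamido group, would give a step beyond the scatter. The compounds shown also leave open how other changes to the shared core would read.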